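Replacing the methylcarbamoyl group of compound 3

The source may report more compounds than this note shows. Statements on the series, on what has been measured and on what is new or still open speak of the compounds shown alone.

Compound 1 `COC(=O)CO/N=C(\C)c1ccc(Cl)cc1`: 24 mg/kg
Compound 2 `C/C(=N\OCC(N)=O)c1ccc(Cl)cc1`: 24 mg/kg
Compound 3 `CNC(=O)CO/N=C(\C)c1ccc(Cl)cc1`: 70 mg/kg

All three compounds were tested in a functional assay on the whole organism for inhibition, with Rattus norvegicus as the target, read by paw edema, with stated times of 1 h and 3 h; a higher number here means that more compound is needed for the effect, a lower number that less compound is needed. Compound 3 has the highest number of the three. Its position rests on two modest steps, a 2.9-fold higher number from compound 1 to compound 3 (0.46 log units; beyond the scatter) and a 2.9-fold higher number from compound 2 to compound 3 (0.46 log units; beyond the scatter). Amino in place of methoxy on a carbonyl carbon gives no change at the digits printed from compound 1 to compound 2 (within the scatter).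

Compound 4 `CC(=O)OCCO/N=C(\C)c1ccc(Cl)cc1` departs from compound 3 in one place: acetoxymethyl in place of methylcarbamoyl on a saturated chain carbon bound to an oxygen on an unsaturated carbon. Acetoxymethyl stands in place of methylcarbamoyl on a saturated chain carbon bound to an oxygen on an unsaturated carbon. Going by the values given here, no measured step makes this exact exchange, so the evidence is indirect. Compound 4 is an ester rather than an amide, as is compound 1, and a 2.9-fold higher number from compound 1 to compound 3 (0.46 log units; beyond the scatter) is the closest measured comparison. Read in reverse, that step suggests that leaving the methyl amide may bring the number down by a modest amount. The acetoxymethyl group itself has not been measured on the shared core, so the range stays wide. The estimated change is a 2.0-fold lower number from compound 3 to compound 4 (0.30 log units; within the scatter), a modest move toward a lower number. For compound 4 the expected value is 35 mg/kg, with an estimated range from 14 mg/kg to 90 mg/kg.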

Compound 4, dose for half-maximal effect: 43 mg/kg
Compound 4: middle estimate off by 1.2-fold (0.09 log units), on the low side; the range from low to high includes it.
By their numbers in this assay, from the lowest: compounds 1, 2, 4 and 3 (each within the scatter of the next, the first and the last beyond it).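

On the saturated chain carbon bound to an oxygen on an unsaturated carbon, exchanging methylcarbamoyl for acetoxymethyl in this assay gives a step that stays within the scatter (a 1.6-fold lower number from compound 3 to compound 4 (0.21 log units; within the scatter)), so this exchange cannot be told apart from repeated measurement. Acetoxymethyl is also not separated from the carbamoyl of compound 2 (a 1.8-fold higher number from compound 2 to compound 4 (0.25 log units; within the scatter)) or the methoxycarbonyl of compound 1 (a 1.8-fold higher number from compound 1 to compound 4 (0.25 log units; within the scatter)), which shows that this place accepts an ester reaching further along the chain without a step beyond the scatter, and that compound 4 sits within the scatter of all three earlier compounds, while compound 3 remains beyond it from compound 1 and compound 2. Nothing shown here offers an explanation for these results.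

The compounds shown leave open whether a free carboxylic acid, a primary amine or a simple hydroxyethyl group at this place would give a step beyond the scatter. They also leave open whether an ethyl amide or a dimethyl amide would follow compound 3 or stay with compound 2.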